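Swapping the Amine on the Propyl Chain

A few compounds are considered here, and "the series" means these few. Any claim that something is new, unique, unknown or untested is made for them only; others in the source may bear on it.

compound 1 `CC(=O)Oc1ccc(C(=O)Nc2cc3ccc(OCCC4CCCCN4)c(C)c3oc2=O)cc1CC=C(C)C`: 640 nM
compound 2 `CC(=O)Oc1ccc(C(=O)Nc2cc3ccc(OCC4CCCNC4)c(C)c3oc2=O)cc1CC=C(C)C`: 620 nM
compound 3 `CCNCCCOc1ccc2cc(NC(=O)c3ccc(O)c(CC=C(C)C)c3)c(=O)oc2c1C`: 720 nM

In a functional assay on SK-BR-3 cells (Homo sapiens) for antiproliferative activity (on this read-out higher numbers stand for weaker inhibition and lower numbers for stronger inhibition), compound 3 gives 720 nM, which lies within the scatter of both other compounds. Compound 4 `CC(C)=CCc1cc(C(=O)Nc2cc3ccc(OCCCN(C)C(C)C)c(C)c3oc2=O)ccc1O` has not yet been measured. It differs from compound 3 in one place: isopropyl(methyl)amino in place of ethylamino on a saturated chain carbon, three bonds along the chain from an oxygen on an aromatic ring. That is, isopropyl(methyl)amino stands in place of ethylamino on a saturated chain carbon, three bonds along the chain from an oxygen on an aromatic ring.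

Going by the values given here, no measured step covers this exact exchange. The closest evidence is a 1.0-fold lower number from compound 1 to compound 2 (0.01 log units; within the scatter), a different change in the group carried on the same oxygen, and it stayed within the scatter. Compound 3, with its own ethylamino chain, also stays within the scatter of compound 1 and compound 2. On this limited evidence, no shift beyond the scatter is expected in this assay. The expected step is a 1.0-fold lower number from compound 3 to compound 4 (0.01 log units; within the scatter). Compound 4 is estimated at 700 nM, with an expected range of 330 nM to 1500 nM.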

Compound 4, half-maximal inhibitory concentration: 570 nM
Compound 4: the middle estimate sits 1.2-fold (0.09 log units) above what was measured, and the stated range covers the measured number.
By their numbers in this assay, from the lowest: compounds 4, 2, 1 and 3 (each within the scatter of the next).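

Going by these compounds alone, this is the first direct read of a change to the amine at the end of the 3-(ethylamino)propyl chain: in this assay the exchange gives a 1.3-fold lower number from compound 3 to compound 4 (0.10 log units; within the scatter) and so stays within the scatter. Ethylamino carries 1 hydrogen-bond donor and 3 heavy atoms while isopropyl(methyl)amino carries 0 and 5, so for this pair neither the loss of that donor nor the larger group moves the number beyond the scatter. Nothing at hand gives a measured reason for this outcome.

Going by these compounds, whether a carboxylic acid in place of the amine, or a chain longer than propyl, would shift the number beyond the scatter remains open. The same holds for a morpholine on this chain, since only open-chain amines have been compared here in a single-place step.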